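Swapping Bromine for Fluorine on Two Related Cores

This account rests on a few compounds, and the source may have more. Where it says the series, first, only, none or still open, it means among the compounds named here.

Compound 1 `CC(=O)Oc1ccc(/C=C/C(=O)NCCCSc2nc(-c3ccc(S(C)(=O)=O)cc3)n(-c3ccc(Br)cc3)n2)cc1OC(C)=O` and compound 2 `CC(=O)Oc1ccc(/C=C/C(=O)NCCCSc2nc(-c3ccc(S(C)(=O)=O)cc3)n(-c3ccc(F)cc3)n2)cc1OC(C)=O` share one core and differ in a single place: fluoro in place of bromo on an aromatic carbon. In an assay on cells (strain Sprague-Dawley) for inhibition of Polyunsaturated fatty acid 5-lipoxygenase (Rattus norvegicus), with a stated time of 30 min (a higher number here means a weaker inhibitor, a lower number a stronger inhibitor), compound 1 gives 990 nM, and compound 2 gives 980 nM, so this change produced a 1.0-fold lower number from compound 1 to compound 2 (0.00 log units; within the scatter). Compound 3 `COc1cc(/C=C/C(=O)OCCSc2nc(-c3ccc(S(C)(=O)=O)cc3)n(-c3ccc(Br)cc3)n2)ccc1OC(C)=O` is built on a different core; how that core differs from the core of compound 1 is not broken down here. In this assay compound 3 gives 940 nM. Compound 4 `COc1cc(/C=C/C(=O)OCCSc2nc(-c3ccc(S(C)(=O)=O)cc3)n(-c3ccc(F)cc3)n2)ccc1OC(C)=O` has not been measured and differs from compound 3 by the same change, (fluoro in place of bromo on an aromatic carbon), at the same place. Because the step of a 1.0-fold lower number from compound 1 to compound 2 (0.00 log units; within the scatter) stayed within the scatter, the same change on the core of compound 3 is expected to behave alike. In this assay compound 4 is therefore estimated at 940 nM, likely between 470 nM and 1900 nM, which means an expected step of no change at the digits printed from compound 3 to compound 4 (within the scatter).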

Compound 4, half-maximal inhibitory concentration: 920 nM
Compound 4: the middle estimate sits 1.0-fold (0.01 log units) above what was measured; the measured number falls inside the stated range.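

In this assay, the swap from 4-bromophenyl to 4-fluorophenyl on the core of compound 3 gives a 1.0-fold lower number from compound 3 to compound 4 (0.01 log units; within the scatter). Set beside the earlier step, the same swap reads alike on both cores: the same change on two cores in this assay, a 1.0-fold lower number (0.00 log units; within the scatter) from compound 1 to compound 2 and a 1.0-fold lower number (0.01 log units; within the scatter) from compound 3 to compound 4, 1.0-fold (0.00 log units) apart, within the scatter of two such steps This shows that the swap leaves the number in this assay essentially unchanged on these two cores, but it does not show the same for other cores or other assays, and because neither step moved the number, it cannot show whether a change with a real effect would carry across.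

Only bromo and fluoro appear at this place in the compounds shown. On these data alone, what a nitrile, a methoxy group or an amine would do there remains open.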